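Replacing a butyl chain with a tert-butylphenyl ring

A few compounds are considered here, and "the series" means these few. Any claim that something is new, unique, unknown or untested is made for them only; others in the source may bear on it.

Measured compounds:
- compound 1, `Nc1nc(Cc2ccccc2)c(-c2ccccc2Br)n1CC(=O)Nc1ccccc1`, 5700 nM
- compound 2, `Cc1ccc(Cc2nc(N)n(CC(=O)Nc3ccccc3)c2-c2ccccc2Br)cc1`, 9200 nM
- compound 3, `CCCCCc1nc(N)n(CC(=O)Nc2ccc(C)cc2)c1-c1ccccc1Br`, 5600 nM

These three compounds share a core and were tested in a functional assay on MIA PaCa-2 cells (Homo sapiens) for antiproliferative activity, read by MTT assay, with a stated time of 48 h; a higher number here means a weaker inhibitor, a lower number a stronger inhibitor. Compound 3 gives the lowest of the three numbers, but its gap to compound 1 and to compound 2 lies within the scatter, so no order among them can be claimed. Within the data shown here, the only step between compounds differing in one place, a 1.6-fold higher number from compound 1 to compound 2 (0.21 log units; within the scatter), is also within the scatter.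

Compound 4, `Cc1ccc(NC(=O)Cn2c(N)nc(Cc3ccc(C(C)(C)C)cc3)c2-c2ccccc2Br)cc1`, has not yet been measured. Its change from compound 3 is 4-(tert-butyl)phenyl in place of butyl on a saturated chain carbon bound to an aromatic carbon. Among the measured compounds shown here, no measured step concerns this kind of change; the step from compound 1 to compound 2 touches a different part of the molecule, and compound 1 and compound 3, which carry a benzyl and a pentyl at this place, differ in a second position as well and show values within the scatter of each other. The expected step of a 1.1-fold higher number from compound 3 to compound 4 (0.03 log units; within the scatter) is therefore one of no size beyond the scatter. Compound 4 is estimated at 6000 nM, with a range from 2500 nM to 15000 nM.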

Compound 4, half-maximal inhibitory concentration: 3400 nM
The estimate for compound 4 lay 1.8-fold (0.25 log units) above the measured number; the range from low to high includes it.
By their numbers in this assay, from the lowest: compounds 4, 3, 1 and 2 (each within the scatter of the next, the first and the last beyond it).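

In this assay, putting 4-(tert-butyl)phenyl in place of butyl, on a saturated chain carbon bound to an aromatic carbon, gives a 1.6-fold lower number from compound 3 to compound 4 (0.22 log units; within the scatter), a step that lies within the scatter. This is the only step shown at this position in which nothing else changes, and it is a large exchange in structural terms: the entering group has 10 heavy atoms and one six-membered aromatic ring, while the butyl has 4 heavy atoms and no ring, yet the two compounds cannot be told apart in this read-out. Nothing measured here accounts for the size of this step.

As far as these compounds go, it remains open whether a group of a different kind at this place, such as a carboxylic acid or an amine in place of the tert-butyl on the ring, or a longer chain such as octyl, would shift the number beyond the scatter. Also open, from the compounds shown here alone, is whether the same exchange would give a step of similar size on a compound with a plain phenyl on the amide nitrogen, as in the core of compound 1.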